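The compounds below may be only part of what the source reports. "The series", "measured", "known", "first", "only" and "open" are said of these compounds alone.

Working notes on the series. The shared core, a bis(trifluoromethyl)phenyl sulfonamide carrying a diamine chain, is held constant; the variation lies in the aryl group on the saturated chain carbon bound to the amine nitrogen. Compound 1 `O=S(=O)(NCCNCc1ccc(-c2ccccc2)cc1)c1cc(C(F)(F)F)cc(C(F)(F)F)c1` and compound 2 `O=S(=O)(NCCCNCc1ccc(Cl)c(C(F)(F)F)c1)c1cc(C(F)(F)F)cc(C(F)(F)F)c1` have been measured in a functional assay on BE(2)-C cells (Homo sapiens) for inhibition, read by MTT assay, with a stated time of 72 h; on this read-out higher numbers stand for weaker inhibition of growth and lower numbers for stronger inhibition of growth. In this assay compound 1 gives 2700 nM, while compound 2 gives 8600 nM. Compound 2 therefore stands as the higher of the two numbers, and its gap to compound 1 lies beyond the usual scatter of repeats, so compound 2 is the weaker of the two on this read-out.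

Compound 3 `COc1ccccc1CNCCCNS(=O)(=O)c1cc(C(F)(F)F)cc(C(F)(F)F)c1` is not yet measured. Relative to compound 2 it differs in one place: 2-methoxyphenyl in place of 4-chloro-3-(trifluoromethyl)phenyl on a saturated chain carbon bound to an amine nitrogen. Within the data shown here, no measured pair shows this particular change, so the expectation rests on compound 2 alone. The step from compound 2 to compound 3 is expected to be a 1.4-fold lower number from compound 2 to compound 3 (0.16 log units; within the scatter), that is, no change beyond the scatter in either direction. For compound 3 the estimate in this assay is 6000 nM, with a range from 2000 nM to 18000 nM.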

Compound 3, concentration for 50% growth inhibition: 3600 nM
The estimate for compound 3 lay 1.7-fold (0.22 log units) above the measured number; measured number inside the range.
By their numbers in this assay, from the lowest: compounds 1 and 3 (each within the scatter of the next); then compound 2.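

In this assay, among these compounds, a 2.4-fold lower number from compound 2 to compound 3 (0.38 log units; beyond the scatter) is the first change read in one place alone, and it shows that the aryl group on a saturated chain carbon bound to an amine nitrogen can shift growth inhibition with the rest of the structure held constant. 2-Methoxyphenyl in place of 4-chloro-3-(trifluoromethyl)phenyl removes the chlorine and all the fluorine of that group, lowers its heavy-atom count and adds a hydrogen-bond acceptor, and the number still moves towards stronger inhibition, so the halogens of the leaving group are not needed for the activity of compound 3. Nothing at hand explains the step or separates these differences from one another.

Compound 1 differs from compound 2 and from compound 3 in both its chain and its aryl group, so the contribution of each part to its number remains unresolved. Also open, on these data alone, is how this position would respond to an unsubstituted phenyl, a pyridine ring or a carboxylic acid on the aryl ring, and how the chain would respond to a longer chain with the aryl group held constant.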